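A few compounds are considered here, and "the series" means these few. Any claim that something is new, unique, unknown or untested is made for them only; others in the source may bear on it.

Compound 1 `C=CCCCCCCS(=O)(=O)/C=C/c1ccc(O)c(O)c1` gives 6400 nM in a functional assay, read by fluorescence and spectrophotometry, with a stated time of 1 h; on this read-out lower numbers stand for an effect already at smaller amounts and higher numbers for an effect only at larger amounts of compound. Compound 3 `CCCCCCCCS(=O)(=O)/C=C/c1ccc(O)c(O)c1` gives 6400 nM in this assay, and compound 2 `CCCCCCCCCCCS(=O)(=O)/C=C/c1ccc(O)c(O)c1` gives 11400 nM. Compound 1 thus stands level with compound 3 at the digits shown, the two together at the low end of the three numbers; the widest gap in the set is a 1.8-fold higher number from compound 1 to compound 2 (0.25 log units; within the scatter). Compound 4 `C=CCCCCCS(=O)(=O)/C=C/c1ccc(O)c(O)c1` has not yet been measured in this assay; it differs from compound 1 by vinyl in place of allyl on a saturated chain carbon, five bonds along the chain from a sulfonyl sulfur. The chain changes seen so far, no change at the digits printed from compound 1 to compound 3 (within the scatter) and a 1.8-fold lower number from compound 2 to compound 3 (0.25 log units; within the scatter), all lie within the scatter, so for compound 4 a step of no change at the digits printed from compound 1 to compound 4 (within the scatter) is expected, none beyond the scatter. Compound 4 is estimated at 6400 nM, with a range from 3200 nM to 12800 nM.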

Compound 4, half-maximal effective concentration: 7100 nM
For compound 4 the middle estimate is 1.1-fold (0.05 log units) below the measured one; measured number inside the range.
By their numbers in this assay, from the lowest: compounds 1, 3, 4 and 2 (each within the scatter of the next).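

Vinyl in place of allyl on a saturated chain carbon, five bonds along the chain from a sulfonyl sulfur, gives a 1.1-fold higher number from compound 1 to compound 4 (0.05 log units; within the scatter) in this assay, so this change stays within the scatter. The saturated chains give the same reading, with a 1.1-fold higher number from compound 3 to compound 4 (0.05 log units; within the scatter) and a 1.6-fold lower number from compound 2 to compound 4 (0.21 log units; within the scatter) both within the scatter, and compound 4 is not separated from any of the other three compounds. No evidence bears on this result.

As far as these compounds go, whether an amine or a carboxylic acid in place of vinyl at this position would give a step beyond the scatter remains open.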